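A few compounds are considered here, and "the series" means these few. Any claim that something is new, unique, unknown or untested is made for them only; others in the source may bear on it.

In a functional assay on HCT-116 cells (Homo sapiens) for inhibition, read by sulforhodamine B assay, with a stated time of 48 h, tested at 50 uM (a lower number here means less inhibition of growth, a higher number more inhibition of growth at the concentration tested), compound 1 (`COc1cc(/C=C/C(=O)/C=C/c2cccc3ccccc23)ccc1OCc1cn(CCCOc2cc(=O)oc3ccccc23)nn1`) gives 66% and compound 2 (`COc1ccc(/C=C/C(=O)/C=C/c2ccc(OCc3cn(CCCCOc4cc(=O)oc5ccccc45)nn3)c(OC)c2)cc1OC`) gives 55% as the lower of the two numbers. The gap between them lies beyond the usual scatter. These two compounds differ in more than one place, so their gap cannot be assigned to any single structural change.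

Compound 3 (`COc1cccc(/C=C/C(=O)/C=C/c2ccc(OCc3cn(CCCCOc4cc(=O)oc5ccccc45)nn3)c(OC)c2)c1`) has not yet been measured. It departs from compound 2 in one place only: hydrogen in place of methoxy on an aromatic carbon with hydrogen in place of methoxy on an aromatic carbon, which turns 3,4-dimethoxyphenyl into 3-methoxyphenyl. Among the measured compounds shown here, no measured pair in this small set shows this change, so its effect on growth inhibition has no direct precedent here. The forecast therefore starts from compound 2 at 55% and expects no step beyond the scatter in this assay, in either direction. The expected change, a number 1 percentage points higher from compound 2 to compound 3 (within the scatter) in this estimate, is small and remains uncertain. For compound 3 the estimated value is 56% with a range from 42% to 70% as the expected span.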

Compound 3, percent growth inhibition at one concentration: 44%
Beside the measured number, compound 3's estimate is 12 percentage points above it, and the stated range covers the measured number.
By their numbers in this assay, from the lowest: compound 3; then compound 2; then compound 1.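

In this assay, among the compounds shown here, the step of a number 11 percentage points lower from compound 2 to compound 3 (beyond the scatter) gives the first reading of a single change in this set: hydrogen in place of methoxy on an aromatic carbon, which turns 3,4-dimethoxyphenyl into 3-methoxyphenyl. It shows that this position, ortho to a methoxy group and para to a large group on a six-membered aromatic ring of carbon only, is not indifferent, as in this one pair the compound that keeps the methoxy gives more growth inhibition at the concentration tested. Nothing at hand explains the step, and this single pair cannot say what about the methoxy group matters.

As far as these compounds go, it remains open whether another group at this position, such as a hydroxyl, an ethoxy or an amine, would match methoxy, fall to the level of hydrogen or go beyond both. Also open, from the compounds shown here alone, is whether the same change would give a step of similar size on the core of compound 1, which has the shorter chain to the triazole-linked end and differs from compound 2 in more than one place.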